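Cyclopropyl Replaces Methoxyphenyl on the Amine Nitrogen

The source may report more compounds than this note shows. Statements on the series, on what has been measured and on what is new or still open speak of the compounds shown alone.

Of the compounds shown here, three built on one shared core have been measured in a physicochemical assay for lipophilicity, read by HPLC; a lower number here means a more polar compound, a higher number a more lipophilic compound. Compound 1 `COc1ccc(NC[C@@H](O)COc2ccc(N3C[C@H](CNC(C)=O)OC3=O)cc2F)cc1` gives 1.15. Compound 2 `CC(=O)NC[C@H]1CN(c2ccc(OC[C@H](O)CNc3ccccn3)c(F)c2)C(=O)O1` gives 1.6, and compound 3 `CC(=O)NC[C@H]1CN(c2ccc(OC[C@@H](O)CNc3cccnc3)c(F)c2)C(=O)O1` gives 0.02. Compound 1 therefore stands second highest of the three: the step of a number 0.45 log units higher from compound 1 to compound 2 (beyond the scatter) carries pyridin-2-yl in place of 4-methoxyphenyl on an amine nitrogen, while the step of a number 1.58 log units lower from compound 2 to compound 3 (beyond the scatter) leaves compound 3 well beneath compound 1.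

Compound 4 `CC(=O)NC[C@H]1CN(c2ccc(OC[C@H](O)CNC3CC3)c(F)c2)C(=O)O1` has not yet been measured. It differs from compound 1 in one place: cyclopropyl in place of 4-methoxyphenyl on an amine nitrogen. Going by the values given here, no measured step matches this change. Among the compounds with values here, the only step at the same amine nitrogen, a number 0.45 log units higher from compound 1 to compound 2 (beyond the scatter), was modest, whereas the step of a number 1.58 log units lower from compound 2 to compound 3 (beyond the scatter) shows how far a change in that part of the molecule can reach. In this assay compound 4 is expected to sit below compound 1, by a step of a number 0.75 log units lower from compound 1 to compound 4 (beyond the scatter) that clears the scatter. The estimate for compound 4 is 0.4, with a range from -0.3 to 1.1.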

Compound 4, partition coefficient: -0.1
Compound 4: the middle estimate sits 0.50 log units above what was measured; the range from low to high includes it.
By their numbers in this assay, from the lowest: compounds 4 and 3 (each within the scatter of the next); then compound 1; then compound 2.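

At the amine nitrogen, the reach of a change in this assay proves much greater than the first step there suggested: cyclopropyl in place of 4-methoxyphenyl gives a number 1.25 log units lower from compound 1 to compound 4 (beyond the scatter) and is a large step, and cyclopropyl in place of pyridin-2-yl gives a number 1.70 log units lower from compound 2 to compound 4 (beyond the scatter) as a second large one. The remaining comparison gives a number 0.12 log units lower from compound 3 to compound 4 (within the scatter) and so places the cyclopropyl compound level with the pyridin-3-yl compound. An aromatic ring on this nitrogen therefore does not by itself set the number, since compound 3 carries one and compound 4 carries none.

Going by these compounds, how an open-chain group such as isopropyl, or a larger saturated ring such as cyclobutyl, would read on the same nitrogen stays open. The compounds shown come with no measurement that explains any of these steps.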